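Adding a Methyl to the Benzyl Ring of Compound 1

The source may report more compounds than this note shows. Statements on the series, on what has been measured and on what is new or still open speak of the compounds shown alone.

Compound 1 `c1ccc(COc2ccc(OCCOCCNC3CCCC3)cc2)cc1` has been measured in a functional assay on SK-OV-3 cells (Homo sapiens) for inhibition, read by CCK-8 assay, with a stated time of 70 h (on this read-out lower numbers stand for stronger inhibition and higher numbers for weaker inhibition), where compound 1 gives 24800 nM. Compound 3 `COc1cc(OCCOCCNC2CCCC2)ccc1OCc1ccccc1` carries a methoxy in place of hydrogen on an aromatic carbon, and compound 3 gives 44600 nM; the change amounts to a 1.8-fold higher number from compound 1 to compound 3 (0.25 log units; within the scatter). Compound 2 `c1ccc(COc2ccc(OCCOCCOC3CCCC3)cc2)cc1` reaches only a limit of the assay, > 100000 nM. That comparison reads an at least 4.0-fold higher number from compound 1 to compound 2 (0.60 log units; beyond the scatter). Compound 1 thus holds the lowest of the two numbers shown, with compound 3 its nearest neighbour, within the scatter.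

Compound 4 `Cc1ccc(COc2ccc(OCCOCCNC3CCCC3)cc2)cc1` differs from compound 1 by methyl in place of hydrogen on an aromatic carbon. Going by the values given here, no measured step alters this benzyl ring. The closest comparison is the methoxy in place of hydrogen from compound 1 to compound 3, which stayed within the scatter; the step from compound 1 to compound 2 concerns the cyclopentylamino and does not bear directly on a methyl. The expectation is therefore a number close to that of compound 1, with no step beyond the scatter. Compound 4 is estimated at 25000 nM, between 10000 nM and 65000 nM, meaning an expected step of a 1.0-fold higher number from compound 1 to compound 4 (0.00 log units; within the scatter).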

Compound 4, half-maximal inhibitory concentration: 17200 nM
Estimate against measurement, compound 4: 1.5-fold (0.16 log units) above; the range from low to high includes it.
By their numbers in this assay, from the lowest: compounds 4, 1 and 3 (each within the scatter of the next, the first and the last beyond it). At a limit, above all of these: compound 2.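

In this assay, the benzyl ring now has a change of its own, since the methoxy of compound 3 sits on the other aromatic ring: a methyl on an aromatic carbon, para to a large group, gives a 1.4-fold lower number from compound 1 to compound 4 (0.16 log units; within the scatter). This step lies within the scatter, so the new carbon on the benzyl ring does not separate compound 4 from compound 1, and neither can be ranked over the other. Nothing on hand bears on why a methyl at this place reads as it does.

Going by these compounds, it remains open whether this carbon would accept a larger or different group, such as an ethyl, an amine or a carboxylic acid, with as little effect on the number. Also open, on these data alone, is whether a methyl on another carbon of the benzyl ring would read like compound 4.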